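The compounds below may be only part of what the source reports. "The series", "measured", "known", "first", "only" and "open" are said of these compounds alone.

Measured compounds in a functional assay on A549 cells (Homo sapiens) for inhibition, read by MTT assay, with a stated time of 24 h; a higher number here means a weaker inhibitor, a lower number a stronger inhibitor:

Compound 1, `O=C(O)C1=Cc2ccccc2OC1(OCc1cc(-c2ccc(F)cc2)no1)C(F)(F)F`: in this assay compound 1 gives > 150000 nM, which is a limit of the assay and not a number.
Compound 2, `CCOC(=O)C1=Cc2ccccc2OC1(OCc1cn(CC(=O)Nc2ccc(C)cc2)nn1)C(F)(F)F`: compound 2 gives 54300 nM.
Compound 3, `CCOC(=O)C1=Cc2ccccc2OC1(OCc1cn(CC(=O)Nc2ccccc2F)nn1)C(F)(F)F`: compound 3 gives 50100 nM.

Compound 1 carries the free acid and the isoxazole-linked aryl group; its result sits at the limit of > 150000 nM in this assay, at which 1 of the 3 values shown sits, so its standing in the series is known only as that limit, with no number beneath it. Compound 4, `COc1ccc(-c2cc(COC3(C(F)(F)F)Oc4ccccc4C=C3C(=O)O)on2)cc1`, is the next entry to be measured and is built from compound 1 by methoxy in place of fluoro on an aromatic carbon.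

For the measured compounds named here, the only measured step, a 1.1-fold lower number from compound 2 to compound 3 (0.03 log units; within the scatter), concerns an amide-type nitrogen substituent on the ethyl-ester triazole pair and does not touch the change from compound 1 to compound 4; it is in any case within the scatter. Going by the values given here, no measured step therefore bears on the methoxy-for-fluoro exchange, and compound 1 itself supplies only a limit. On that footing compound 4 is expected to come out near the same limit, with the step that the limit leaves unreadable from compound 1 to compound 4 estimated as no change beyond the scatter. The estimate for compound 4 is therefore 160000 nM, within 60000 nM to 400000 nM.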

Compound 4, half-maximal inhibitory concentration: 36200 nM
The estimate for compound 4 lay 4.4-fold (0.65 log units) above the measured number; measured number below the stated range.
By their numbers in this assay, from the lowest: compounds 4, 3 and 2 (each within the scatter of the next). At a limit, above all of these: compound 1.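

In this assay, 4-methoxyphenyl in place of 4-fluorophenyl on the isoxazole-linked free acid gives an at least 4.1-fold lower number from compound 1 to compound 4 (0.61 log units; beyond the scatter), which lies beyond the scatter. For the compounds shown here, this position, on an aromatic carbon para to a large group, is therefore one where a single exchange moves the read-out, something the only earlier step, a 1.1-fold lower number from compound 2 to compound 3 (0.03 log units; within the scatter), did not show: that step lay within the scatter and concerned an amide-type nitrogen substituent in a different pair. The full size of the new step stays unknown because its starting point is a limit of the assay and not a number: the limit of > 150000 nM in this assay, at which 1 of the 4 values shown sits.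

Open, as far as these compounds go, is whether a hydroxyl group, an ethoxy group or plain hydrogen at this same place would stay at the level of compound 4 or return to the limit, so that one exchange does not yet make a trend. Also open, from the compounds shown here alone, is what an ethyl ester would do on the isoxazole-linked 4-methoxyphenyl scaffold of compound 4, which differs from compound 2 and compound 3 in more than one place and so cannot yet be compared with them.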